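This account rests on a few compounds, and the source may have more. Where it says the series, first, only, none or still open, it means among the compounds named here.

Compound 1 `CC(=O)OCc1ccc2oc(=O)c(C(=O)Oc3cccc(Cl)c3)cc2c1` was tested in a functional assay on HT-1080 cells (Homo sapiens), read by transwell migration, with a stated time of 24 h, tested at 10 uM (a higher number here means a weaker effect of the compound at the concentration tested, a lower number a stronger effect), where compound 1 gives 6.17%. Within the data shown here, this is the lowest of the two numbers measured so far, which here means the stronger effect. Among the measured compounds shown here, the only other measured compound is compound 2 `CC(=O)OCc1ccc2oc(=O)c(C(=O)Sc3ccccc3)cc2c1`, which in this assay gives 73.8%. For the measured compounds named here, the one measured step between them, a number 67.6 percentage points higher from compound 1 to compound 2 (beyond the scatter), concerns phenylsulfanyl in place of 3-chlorophenoxy on a carbonyl carbon, and it is a large step.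

The next compound, compound 3 `O=C(Oc1cccc(Cl)c1)c1cc2cc(CCl)ccc2oc1=O`, differs from compound 1 at a different place: chloro in place of acetoxy on a saturated chain carbon bound to an aromatic carbon. Going by the values given here, the step from compound 1 to compound 2 changes another part of the shared core, so it does not bear on this exchange; no measured step does. Among the compounds with values here, with nothing to go on beyond the structures and the single known value, the expectation is that compound 3 stays near compound 1 in this assay, with a step of a number 8.8 percentage points higher from compound 1 to compound 3 (within the scatter) that may well remain within the scatter. Compound 3 is therefore estimated at 15%, with a range from 3% to 45%.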

Compound 3, a percentage reported as activity, at one concentration (the size of the read-out at that concentration, not a potency): 67%
Estimate against measurement, compound 3: 52 percentage points below; measured number above the stated range.
By their numbers in this assay, from the lowest: compound 1; then compounds 3 and 2 (each within the scatter of the next).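

In this assay the acetoxymethyl position turns out to matter as well: with the 3-chlorophenoxy group kept, chloro in place of acetoxy on this saturated chain carbon gives a number 60.8 percentage points higher from compound 1 to compound 3 (beyond the scatter) and a large step beyond the scatter. Until now, only a change at the carbonyl carbon had been seen to shift the number, and this result shows that keeping 3-chlorophenoxy is not enough to hold the strong effect of compound 1. No measurement available here explains this step, and nothing shown links it to any particular property of acetoxy or chloro.

The single exchange removes acetoxy and brings in chloro at once, so the compounds shown cannot separate what is lost with acetoxy from what chloro adds. A hydroxyl group, an amine or a longer ester such as propanoyloxy on the same carbon would help to show whether the strong effect is specific to acetoxy or is shared by other groups at this place.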